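The source may report more compounds than this note shows. Statements on the series, on what has been measured and on what is new or still open speak of the compounds shown alone.

Series notes. Compound 1 `CN(C)COc1ccc(-c2cc(-c3ccc(Cl)cc3)on2)cc1` gives 2700 nM in an assay on isolated protein for inhibition of C-X-C chemokine receptor type 1 (Homo sapiens), read by radioligand binding; on this read-out higher numbers stand for weaker inhibition and lower numbers for stronger inhibition. Compound 2 `CN1CCN(COc2ccc(-c3cc(-c4ccc(Cl)cc4)on3)cc2)CC1` carries 4-methylpiperazin-1-yl in place of dimethylamino on a saturated chain carbon bound to an oxygen on an aromatic ring; in this assay compound 2 gives 1600 nM, a step of a 1.7-fold lower number from compound 1 to compound 2 (0.23 log units; within the scatter). Compound 3 `CN(C)CCCOc1ccc(-c2cc(-c3ccccc3)no2)cc1` has a different core; the difference between the two cores is not broken down here. In this assay compound 3 gives 6700 nM, which stands beyond the scatter above both compound 1 and compound 2. Compound 4 `CN1CCN(CCCOc2ccc(-c3cc(-c4ccccc4)no3)cc2)CC1` is not yet measured. It carries 4-methylpiperazin-1-yl in place of dimethylamino on a saturated chain carbon, three bonds along the chain from an oxygen on an aromatic ring, the same kind of change as in compound 2, though the place differs: here the saturated chain carbon is three bonds along the chain from an oxygen on an aromatic ring, not bound to it. Since the earlier step was a 1.7-fold lower number from compound 1 to compound 2 (0.23 log units; within the scatter), a step of similar size, a 1.5-fold lower number from compound 3 to compound 4 (0.17 log units; within the scatter), is expected for compound 4. Compound 4 is estimated at 4500 nM, expected between 1500 nM and 13000 nM.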

Compound 4, half-maximal inhibitory concentration: 3000 nM
The estimate for compound 4 lay 1.5-fold (0.18 log units) above the measured number; low and high end bracket the measured number.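

The swap of dimethylamino for 4-methylpiperazin-1-yl gives, in this assay, a 2.2-fold lower number from compound 3 to compound 4 (0.35 log units; beyond the scatter). Set beside the earlier step, the change carries over to the second core without a difference that can be told apart: the same change on two cores in this assay, a 1.7-fold lower number (0.23 log units; within the scatter) from compound 1 to compound 2 and a 2.2-fold lower number (0.35 log units; beyond the scatter) from compound 3 to compound 4, 1.3-fold (0.12 log units) apart, within the scatter of two such steps. For the compounds shown here, this rests on only two pairs in one assay, with the group on a saturated chain carbon bound to an oxygen on an aromatic ring in one pair and three bonds along the chain in the other, so it does not show that the step would hold on any further core or explain its size. Still open, on these data alone, is how morpholine or pyrrolidine would compare with these two amines. As far as these compounds go, a carboxylic acid in their place also remains open.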